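A few compounds are considered here, and "the series" means these few. Any claim that something is new, unique, unknown or untested is made for them only; others in the source may bear on it.

In a functional assay on aorta (Rattus norvegicus, strain Sprague-Dawley) (on this read-out lower numbers stand for an effect already at smaller amounts and higher numbers for an effect only at larger amounts of compound), compound 1 `Cc1nn(-c2ccccc2)c2nc(OCc3ccccc3F)c(-c3nc(N)c(N4CCCCC4)c(N)n3)cc12` gives 790 nM and compound 2 `Cc1nn(-c2ccccc2)c2nc(OCc3ccccc3F)c(-c3nc(N)c(N(C)C)c(N)n3)cc12` gives 1100 nM, which is a 1.4-fold higher number from compound 1 to compound 2 (0.14 log units; within the scatter). Compound 3 `COC(=O)Nc1c(N)nc(-c2cc3c(C)nn(-c4ccccc4)c3nc2OCc2ccccc2F)nc1N`, at 5800 nM, has the highest number of the three, with a 7.3-fold higher number from compound 1 to compound 3 (0.87 log units; beyond the scatter) and a 5.3-fold higher number from compound 2 to compound 3 (0.72 log units; beyond the scatter). Compound 4 `Cc1nn(-c2ccccc2)c2nc(OCc3ccccc3F)c(-c3nc(N)c(NC(=O)OC4CCCC4)c(N)n3)cc12` differs from compound 3 by cyclopentyl in place of methyl on an oxygen next to a carbonyl group. Among the compounds with values here, no measured step alters this group alone. The steps to compound 3 replace the whole substituent, so they only show that changes on that aromatic carbon can be modest in size. No change beyond the scatter is therefore expected, and the expected step is a 1.5-fold lower number from compound 3 to compound 4 (0.16 log units; within the scatter). For compound 4 the estimated value is 4000 nM, with an expected range of 1200 nM to 13000 nM.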

Compound 4, half-maximal effective concentration: > 100000 nM
Compound 4 was reported as a limit; the forecaster's own chance of this, stated with the estimate: 5%; middle value at least 25-fold (1.39 log units) from the limit.
By their numbers in this assay, from the lowest: compounds 1 and 2 (each within the scatter of the next); then compound 3. At a limit, above all of these: compound 4.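

Within the data shown here, changing only the group on this oxygen, from methyl to cyclopentyl, gives a large step, an at least 17-fold higher number from compound 3 to compound 4 (1.23 log units; beyond the scatter), so this outer end of the substituent matters far more than the modest steps among the earlier compounds could show. The (cyclopentyloxycarbonyl)amino group also stands far from the other two substituents, with an at least 90-fold higher number from compound 2 to compound 4 (1.95 log units; beyond the scatter) and an at least 120-fold higher number from compound 1 to compound 4 (2.10 log units; beyond the scatter). In this assay compound 4 gives a limit, not a number: the limit of > 100000 nM in this assay, at which 1 of the 4 values shown sits.

As far as these compounds go, whether ethyl or isopropyl on this oxygen would give a small or a large step remains open. From the compounds shown here alone, the true number for compound 4 also remains open.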